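Adding a Methyl to a Tetracyclic Cytotoxic Scaffold

The source may hold more compounds than are shown below. What is called first, only, known or untested is meant among the compounds shown, and "the series" means these compounds.

Compound 1, `Cc1ccc2c(=O)n(C)c3c(c2c1)CCOc1ccccc1-3`: 41600 nM
Compound 2, `COc1ccc(Cn2c3c(c4ccccc4c2=O)CCOc2ccccc2-3)cc1`: 4780 nM

Both compounds were tested in a functional assay on HeLa cells (Homo sapiens) for cytotoxicity, read by sulforhodamine B assay; a lower number here means a stronger inhibitor, a higher number a weaker inhibitor. Compound 2 gives the lowest of the two numbers; compound 1 sits beyond the scatter above it, so compound 2 is the stronger of the pair.

Compound 3, `COc1ccc(Cn2c3c(c4cc(C)ccc4c2=O)CCOc2ccccc2-3)cc1`, has not been measured. It differs from compound 2 by methyl in place of hydrogen on an aromatic carbon. Going by the values given here, no measured pair isolates this change: compound 1 also carries such a methyl, but it differs from compound 2 in a second place as well, so the two values of that pair give no clean reading of the methyl alone. A single methyl on an aromatic carbon usually shifts numbers of this kind only a little, and with nothing in the data pointing either way the step of a 1.0-fold higher number from compound 2 to compound 3 (0.02 log units; within the scatter) is expected to stay within the scatter. Compound 3 is therefore estimated at 5000 nM, with a range from 1800 nM to 15000 nM.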

Compound 3, half-maximal inhibitory concentration: 10300 nM
Compound 3: the middle estimate sits 2.1-fold (0.31 log units) below what was measured, and the stated range covers the measured number.
By their numbers in this assay, from the lowest: compound 2; then compound 3; then compound 1.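

In this assay the methyl on this aromatic carbon can now be read alone: a 2.2-fold higher number from compound 2 to compound 3 (0.33 log units; beyond the scatter) shows that this single added carbon, with all else held the same, makes the compound modestly weaker. Going by these compounds alone, the group on the ring nitrogen can also be read alone for the first time, since 4-methoxyphenyl in place of hydrogen on the saturated chain carbon bound to an aromatic nitrogen gives a 4.0-fold lower number from compound 1 to compound 3 (0.61 log units; beyond the scatter) with the methyl kept in place. Nothing available explains the direction of either step.

The compounds shown leave open whether a chlorine atom or an amine on the same aromatic carbon would also weaken the compound, or whether any group there could strengthen it. They also leave open whether the methyl step keeps its size with a different group on the ring nitrogen.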